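A few compounds are considered here, and "the series" means these few. Any claim that something is new, unique, unknown or untested is made for them only; others in the source may bear on it.

Measured compounds in an ADME assay on Vero cells (Chlorocebus sabaeus) for cytotoxicity, read by MTT assay, tested at 100 uM; a lower number here means a stronger effect, a higher number a weaker effect of the compound at the concentration tested:
- compound 1 `CSc1ccc(C(=O)/C(=C/c2cc3ccccc3s2)c2ccc(Cl)c(Cl)c2)cc1` gives 87.1%
- compound 2 `CSc1ccc(C(=O)/C(=C/c2cccnc2)c2ccc(Cl)c(Cl)c2)cc1` gives 88.6%
- compound 3 `CCOC(=O)C(C(=O)c1ccc(OC)cc1)C(NC(C)=O)c1ccc(C(C)C)cc1` gives 90.4%

Compound 3 stands with the other two: its gap to compound 2 and its gap to compound 1 both lie within the scatter, so nothing separates the three on this read-out. Compound 4 `CCOC(=O)C(C(=O)c1ccc(OC)cc1)C(NC(C)=O)c1ccc(C(C)(C)C)cc1` has not been measured. It differs from compound 3 by methyl in place of hydrogen on a saturated chain carbon bound to an aromatic carbon and two saturated chain carbons.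

For the measured compounds named here, the only step between measured compounds is a number 1.5 percentage points higher from compound 1 to compound 2 (within the scatter). It concerns a different core and an exchange of ring systems, not a methyl in place of hydrogen on a saturated chain carbon, so it bears on the change from compound 3 to compound 4 only in a general way: it shows that a structural change within this set can leave this assay unmoved. Going by the values given here, no measured step touches the place that changes in compound 4. On that basis the expectation for this assay is no step beyond the scatter in either direction, the expected step being a number 1.4 percentage points lower from compound 3 to compound 4 (within the scatter). Compound 4 is estimated at 89%, with a range from 79% to 97%, set around the number of compound 3 and widened for the absence of any relevant measured step.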

Compound 4, a percentage reported as activity, at one concentration (the size of the read-out at that concentration, not a potency): 89.5%
Beside the measured number, compound 4's estimate is 0.5 percentage points below it, and the stated range covers the measured number.
By their numbers in this assay, from the lowest: compounds 1, 2, 4 and 3 (each within the scatter of the next).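

For the compounds shown here, the exchange of 4-isopropylphenyl for 4-(tert-butyl)phenyl gives, in this assay, a number 0.9 percentage points lower from compound 3 to compound 4 (within the scatter), and this is the first reading at this place. Methyl in place of hydrogen on a saturated chain carbon bound to an aromatic carbon and two saturated chain carbons therefore leaves this assay unmoved on the core of compound 3, which the step between compound 1 and compound 2, an exchange of ring systems on a different core, could not show. Nothing available offers an explanation for this flat result, and it stands as an observation on a single pair.

Still open is whether this place tolerates groups of a different kind in the same way: a carboxylic acid, an amine or a longer chain such as n-butyl in place of tert-butyl could each give a different reading from the two alkyl groups shown. A single pair at a single tested concentration also leaves open whether the same exchange would stay within the scatter on the core of compound 1 or at other concentrations.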